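The source may hold more compounds than are shown below. What is called first, only, known or untested is meant among the compounds shown, and "the series" means these compounds.

For the measured compounds named here, compound 2 `Cn1c(-c2ccc(NC(=O)CSc3nc4ccccc4o3)cc2)nc(-c2ccccc2)c1-c1ccccc1` gives 71.5% in a functional assay on MCF7 cells (Homo sapiens) for cytotoxicity, read by MTT assay, with a stated time of 24 h, tested at 32 ug/mL (on this read-out lower numbers stand for a weaker effect and higher numbers for a stronger effect at the one concentration tested), the highest of the two numbers known here; compound 1 `Cn1c(-c2ccc(NC(=O)CCl)cc2)nc(-c2ccccc2)c1-c1ccccc1` gives 42.8%, and the step of a number 28.7 percentage points higher from compound 1 to compound 2 (beyond the scatter) came with (1,3-benzoxazol-2-yl)sulfanyl in place of chloro on a saturated chain carbon bound to a carbonyl carbon. Compound 3 `Cn1c(-c2ccc(NC(=O)CSc3nc4cc(Cl)ccc4o3)cc2)nc(-c2ccccc2)c1-c1ccccc1` differs from compound 2 by chloro in place of hydrogen on an aromatic carbon. Going by the values given here, no measured step alters the 1,3-benzoxazol-2-yl ring itself, so nothing measured bears directly on this change, and no step beyond the scatter is expected. The expected step is a number 0.5 percentage points higher from compound 2 to compound 3 (within the scatter). Compound 3 is accordingly estimated at 72%, within 55% to 88%.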

Compound 3, a percentage reported as activity, at one concentration (the size of the read-out at that concentration, not a potency): 59.7%
Compound 3: the middle estimate sits 12.3 percentage points above what was measured; low and high end bracket the measured number.
By their numbers in this assay, from the lowest: compound 1; then compound 3; then compound 2.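

For the compounds shown here, the step to 5-chloro-1,3-benzoxazol-2-yl gives a number 11.8 percentage points lower from compound 2 to compound 3 (beyond the scatter) in this assay, the first sign that changes on this ring can shift the read-out. The (5-chloro-1,3-benzoxazol-2-yl)sulfanyl group still keeps a number 16.9 percentage points higher from compound 1 to compound 3 (beyond the scatter), so the added chloro gives back only part of the gain over the chain chloro. Nothing available explains the drop. On these data alone, whether it is specific to chloro remains open. A methoxy group or an amine on the same ring carbon would help to show this.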